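The compounds below may be only part of what the source reports. "The series", "measured", "known", "first", "only" and "open" are said of these compounds alone.

Measured compounds in a functional assay on the whole organism (strain albino) for inhibition, with Rattus norvegicus as the target, read by paw edema, with stated times of 30 min and 3 h, at a dose of 100 mg/kg by the oral route; on this read-out lower numbers stand for less inhibition and higher numbers for more inhibition at the one dose given (going by the name of the read-out):

compound 1, `COc1ccc(/C=C/C(=O)c2ccc(NC(=O)COc3ccc(/C(C)=N\O)cc3)cc2)cc1`: 46%
compound 2, `C/C(=N/O)c1ccc(OCC(=O)Nc2ccc(C(=O)/C=C/c3ccco3)cc2)cc1`: 49%
compound 3, `COc1ccc(/C=C/C(=O)c2ccc(NC(=O)COCc3c(-c4ccccc4)no[n+]3[O-])cc2)cc1`: 56%

Compound 4, `O=C(COCc1c(-c2ccccc2)no[n+]1[O-])Nc1ccc(C(=O)/C=C/c2ccco2)cc1`, has not yet been measured in this assay.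

Compound 1 and compound 2 share one core. Among the measured compounds shown here, the single change between them is furan-2-yl in place of 4-methoxyphenyl on a double-bonded chain carbon bound to a double-bonded chain carbon, and in this assay it gives a number 3 percentage points higher from compound 1 to compound 2 (within the scatter). Compound 3 carries a different core; the difference between the core of compound 1 and the core of compound 3 is not broken down here. The numbers of compound 3 and compound 2 lie within the scatter of each other in this assay, as do those of compound 3 and compound 1, so no order among the three measured compounds is claimed.

Compound 4 relates to compound 3 exactly as compound 2 relates to compound 1: the change is furan-2-yl in place of 4-methoxyphenyl on a double-bonded chain carbon bound to a double-bonded chain carbon. The place of the change is described in the same words in both pairs, so this is the same change made a second time, on a second core. For the measured compounds named here, only one earlier instance of it exists, and that instance was within the scatter, so the expectation for compound 4 rests on little: it rests on the measured a number 3 percentage points higher from compound 1 to compound 2 (within the scatter) and on the starting point of compound 3 at 56%. The step from compound 3 to compound 4 is therefore expected to be a number 3 percentage points higher from compound 3 to compound 4 (within the scatter), beside the earlier one. Compound 4 is expected to give 59% in this assay, with a range estimated from 48% to 70%.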

Compound 4, a percentage reported as inhibition, in the whole organism at one dose (the size of the read-out at that dose, not a potency): 59%
Beside the measured number, compound 4's estimate shows no gap at the digits printed; the range from low to high includes it.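

In this assay, furan-2-yl in place of 4-methoxyphenyl on a double-bonded chain carbon bound to a double-bonded chain carbon gives a number 3 percentage points higher from compound 3 to compound 4 (within the scatter). Set against the earlier instance of the same change, the second step shows no difference between the two cores: the same change on two cores in this assay, a number 3 percentage points higher (within the scatter) from compound 1 to compound 2 and a number 3 percentage points higher (within the scatter) from compound 3 to compound 4, 0 percentage points apart, within the scatter of two such steps. The exchange of 4-methoxyphenyl for furan-2-yl therefore carries from one core to the other without any visible dependence on the core, but neither step can be told from the scatter, so this agreement does not show that furan-2-yl gives more inhibition than 4-methoxyphenyl, and two cores at one oral dose say nothing about potency or about a third core.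

The compounds shown leave open how this position responds to other groups, such as thiophen-2-yl, pyridin-3-yl or 4-(dimethylamino)phenyl, any of which might give a step large enough to read in this paw edema model. Also open, on these data alone, is whether a group of another kind on the far side of the amide, such as a carboxylic acid or a longer chain, would alter the step seen for this exchange.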